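Lengthening the urea chain on a thromboxane receptor antagonist

The source may report more compounds than this note shows. Statements on the series, on what has been measured and on what is new or still open speak of the compounds shown alone.

Three measured compounds share one core and were tested in a functional assay on HEK293 cells for antagonist activity at thromboxane A2 receptor (Homo sapiens), read by fluorescence and calcium flux; a higher number here means a weaker inhibitor, a lower number a stronger inhibitor. Compound 1 `CCCCCNC(=O)NS(=O)(=O)c1cc(C#N)ccc1Oc1ccc(F)cc1` gives 9430 nM. Within the data shown here, compound 2 `CCCCCNC(=O)NS(=O)(=O)c1cc(C#N)ccc1Nc1ccccc1C` gives 3190 nM, and the single measured step reads a 3.0-fold lower number from compound 1 to compound 2 (0.47 log units; beyond the scatter). Compound 3 `CC(C)NC(=O)NS(=O)(=O)c1cc(C#N)ccc1Nc1ccc(F)cc1` gives 8170 nM, which places it second highest of the three numbers: its gap to compound 1 lies within the scatter, while compound 2 sits beyond the scatter below it.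

The unmeasured compound 4 `CCCCCNC(=O)NS(=O)(=O)c1cc(C#N)ccc1Nc1ccc(F)cc1` differs from compound 3 by pentyl in place of isopropyl on an amide-type nitrogen. Among the measured compounds shown here, no measured step concerns this exchange; the only step measured alters a different part of the molecule. Compounds 1 and 2 both carry the pentyl chain and compound 3 the isopropyl group, yet the value of compound 3 falls between those two, so the data give no direction for the change. A step of no more than the scatter, with some lean toward a lower number, is expected. Compound 4 is therefore expected to give about 6000 nM, between 2500 nM and 14000 nM, an expected step of a 1.4-fold lower number from compound 3 to compound 4 (0.13 log units; within the scatter).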

Compound 4, half-maximal inhibitory concentration: 6780 nM
Beside the measured number, compound 4's estimate is 1.1-fold (0.05 log units) below it; low and high end bracket the measured number.
By their numbers in this assay, from the lowest: compound 2; then compounds 4, 3 and 1 (each within the scatter of the next).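

In this assay, the exchange of isopropyl for pentyl on the amide-type nitrogen gives a 1.2-fold lower number from compound 3 to compound 4 (0.08 log units; within the scatter), so within these compounds a chain of 5 carbons and a branched group of 3 carbons cannot be told apart at this position. With pentyl held fixed, changing the aryl group on the nitrogen does register, as 4-fluorophenyl in place of 2-methylphenyl gives a 2.1-fold higher number from compound 2 to compound 4 (0.33 log units; beyond the scatter), whereas (4-fluorophenyl)amino in place of 4-fluorophenoxy gives a 1.4-fold lower number from compound 1 to compound 4 (0.14 log units; within the scatter) and so stays inside the usual scatter. No measurement available here accounts for any of these steps.

As far as these compounds go, how a longer chain such as octyl, or a chain ending in a carboxylic acid, would behave on this nitrogen remains open. Also open, from the compounds shown here alone, is whether the 2-methylphenyl group would give a similar step with isopropyl on the urea.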